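Chloro for fluoro on the aryl of a pyrimidinyl semicarbazone series

The source may report more compounds than this note shows. Statements on the series, on what has been measured and on what is new or still open speak of the compounds shown alone.

Measured compounds:
compound 1 `COc1ccc(-c2cc(-c3ccc(F)cc3)nc(NC(=O)N/N=C\c3ccc([N+](=O)[O-])cc3)n2)cc1OC`, 300 mg/kg
compound 2 `COc1ccc(-c2cc(-c3ccc(F)cc3)nc(NC(=O)N/N=C\c3ccccc3Cl)n2)c(OC)c1`, 300 mg/kg
compound 3 `COc1ccc(-c2cc(-c3ccc(Cl)cc3)nc(NC(=O)N/N=C\c3ccc([N+](=O)[O-])cc3)n2)cc1OC`, 100 mg/kg

All three were run in a functional assay on the whole organism (strain Albino) with Mus musculus as the target, with a stated time of 4 h; a lower number here means that less compound is needed, a higher number that more compound is needed for the effect. In this assay compound 1 gives 300 mg/kg and compound 2 gives 300 mg/kg; the two stand level at the digits reported, together the highest of the three numbers. Compound 3 gives 100 mg/kg, the lowest of the three.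

One single-point change is seen among the measured compounds: chloro in place of fluoro on an aromatic carbon, which produced a 3.0-fold lower number from compound 1 to compound 3 (0.48 log units; beyond the scatter). The difference between the cores of compound 1 and compound 2 is not broken down here.

Compound 4 `COc1ccc(-c2cc(-c3ccc(Cl)cc3)nc(NC(=O)N/N=C\c3ccccc3Cl)n2)c(OC)c1` has not yet been measured in this assay. It differs from compound 2 by chloro in place of fluoro on an aromatic carbon, the same change that separates compound 1 from compound 3, made at a place described in the same words. Going by the values given here, the expectation for compound 4 therefore rests on compound 2 and the single earlier step, and a step from compound 2 to compound 4 of a 3.0-fold lower number from compound 2 to compound 4 (0.48 log units; beyond the scatter) is expected because a 3.0-fold lower number from compound 1 to compound 3 (0.48 log units; beyond the scatter) is the only guide available. Whether the change carries over onto the core of compound 2 is not shown by the data, so the range is kept wide. Compound 4 is expected to give 100 mg/kg, between 50 mg/kg and 250 mg/kg.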

Compound 4, dose for half-maximal effect: 300 mg/kg
Beside the measured number, compound 4's estimate is 3.0-fold (0.48 log units) below it; measured number outside the range, above it.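

In this assay the change from 4-fluorophenyl to 4-chlorophenyl does not behave as a portable step across these two cores: the same change on two cores in this assay, a 3.0-fold lower number (0.48 log units; beyond the scatter) from compound 1 to compound 3 and no change at the digits printed (within the scatter) from compound 2 to compound 4, 3.0-fold (0.48 log units) apart, beyond the scatter of two such steps

On the core of compound 2, the exchange gives no change at the digits printed from compound 2 to compound 4 (within the scatter), so the benefit seen with the nitro-bearing pair is not a general feature of this exchange across the compounds shown, and compound 4 goes against any such pattern. The data do not show which feature of the cores decides the outcome, as the core of compound 1 and the core of compound 2 differ both in the arrangement of the methoxy groups and in the aryl group carrying nitro or chloro, and two pairs cannot separate these differences or show how the exchange would behave on any further core.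

The compounds shown leave open whether the exchange would pay on a core combining the nitro-bearing aryl of compound 1 with the methoxy arrangement of compound 2, or the reverse combination, which would assign the difference to one feature. Also open, from the compounds shown here alone, is how a bromo or trifluoromethyl group would read at the same place, and how an amine or a carboxylic acid would read in place of the nitro group.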